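A few compounds are considered here, and "the series" means these few. Any claim that something is new, unique, unknown or untested is made for them only; others in the source may bear on it.

Compound 1 `O=C1C(=O)N(Cc2ccc(-c3ccccc3)cc2)c2ccc(OC(F)(F)F)cc21` is examined in a functional assay on CHO cells for positive allosteric modulation of muscarinic acetylcholine receptor M5 (Homo sapiens), read by FLIPR and calcium flux, with a stated time of 1 h (on this read-out lower numbers stand for an effect already at smaller amounts and higher numbers for an effect only at larger amounts of compound), where compound 1 gives 1600 nM. Within the data shown here, its only measured neighbour, compound 2 `O=C1C(=O)N(Cc2ccc(Oc3nccs3)cc2)c2ccc(OC(F)(F)F)cc21`, gives 2800 nM, and the step of a 1.8-fold higher number from compound 1 to compound 2 (0.24 log units; within the scatter) leaves the two on a par. Compound 3 `O=C1C(=O)N(Cc2ccc(-c3ccccc3)cc2F)c2ccc(OC(F)(F)F)cc21` differs from compound 1 by fluoro in place of hydrogen on an aromatic carbon. Among the measured compounds shown here, no measured step involves this change, and the single known step concerns a different part of the molecule, so no shift beyond the scatter is expected: the estimated step is no change at the digits printed from compound 1 to compound 3 (within the scatter). Compound 3 is therefore expected to give about 1600 nM, between 700 nM and 3600 nM.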

Compound 3, half-maximal effective concentration: 5900 nM
Estimate against measurement, compound 3: 3.7-fold (0.57 log units) below; the whole stated range lies below it.
By their numbers in this assay, from the lowest: compounds 1 and 2 (each within the scatter of the next); then compound 3.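

Fluoro in place of hydrogen on this aromatic carbon, ortho to a large group and meta to a phenyl group, brings a 3.7-fold higher number from compound 1 to compound 3 (0.57 log units; beyond the scatter) in this assay. A single fluorine atom here therefore moves the number beyond the scatter, whereas replacing the phenyl group with (1,3-thiazol-2-yl)oxy gave a 1.8-fold higher number from compound 1 to compound 2 (0.24 log units; within the scatter). Nothing shown bears on the reason for this rise. From the compounds shown here alone, whether chloro, methoxy or an amine in this place would raise the number too remains open. So does the effect of fluoro on another carbon of this ring.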